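A few compounds are considered here, and "the series" means these few. Any claim that something is new, unique, unknown or untested is made for them only; others in the source may bear on it.

Measured compounds, with their values in a functional assay on HEK293 cells for activation of melanin-concentrating hormone receptor 1 (Homo sapiens), read by inositol phosphate accumulation; on this read-out lower numbers stand for an effect already at smaller amounts and higher numbers for an effect only at larger amounts of compound:
- compound 1, `CCCc1cc(N)c2cc(NC(=O)/C=C/c3ccc(C(C)(C)C)cc3)ccc2n1`: 910 nM
- compound 2, `CCCc1cc(N)c2cc(NC(=O)c3ccc(-c4ccc(Cl)cc4)cc3)ccc2n1`: 75 nM
- compound 3, `Nc1cc(C2CCC2)nc2ccc(NC(=O)/C=C/c3ccc(C(F)(F)F)cc3)cc12`: 250 nM

Compound 3 stands second highest of the three values in this assay: compound 2 sits nearer, with a lower number that is beyond the scatter, and compound 1 sits furthest, with a higher number that is also beyond the scatter.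

Compound 4, `Cc1cc(N)c2cc(NC(=O)/C=C/c3ccc(C(F)(F)F)cc3)ccc2n1`, differs from compound 3 by a single change: methyl in place of cyclobutyl on an aromatic carbon. For the measured compounds named here, no measured pair of compounds shows this change, so no step size is known for it. The expected step from compound 3 to compound 4 in this assay is a 2.0-fold higher number from compound 3 to compound 4 (0.30 log units; within the scatter), a modest rise in the number, a loss of potency not far beyond the scatter. Compound 4 is estimated at 500 nM, within a range from 150 nM to 1500 nM.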

Compound 4, half-maximal effective concentration: 140 nM
The estimate for compound 4 lay 3.6-fold (0.55 log units) above the measured number; the measured number lies below the stated range.
By their numbers in this assay, from the lowest: compounds 2, 4 and 3 (each within the scatter of the next, the first and the last beyond it); then compound 1.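

In this assay, the step of a 1.8-fold lower number from compound 3 to compound 4 (0.25 log units; within the scatter) gives the series its first pair differing in one place, and cyclobutyl and methyl on this aromatic carbon next to the ring nitrogen cannot be told apart. Going from 4 heavy atoms and a ring to 1 heavy atom and no ring at this place therefore gives no change beyond the scatter, with the rest of the structure held constant. No supporting data offer an explanation for this result.

Going by these compounds, whether an amine or a carboxylic acid on this carbon would fit the same picture remains open. Also open, on these data alone, is whether methyl and cyclobutyl would still match with the amide side chain of compound 2.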